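Fluorine at the Aryl Ring: From Compound 2 to Compound 3

The source may report more compounds than this note shows. Statements on the series, on what has been measured and on what is new or still open speak of the compounds shown alone.

Two compounds share one core and carry an aryl group on it. Compound 1 `CCOc1ccc(-c2ncnc3c2ncn3C2O[C@H](CO)[C@@H](O)[C@H]2O)cc1` bears a 4-ethoxyphenyl and in a functional assay on CCRF-CEM cells (Homo sapiens) for inhibition (on this read-out lower numbers stand for stronger inhibition and higher numbers for weaker inhibition), compound 1 gives 600 nM. Within the data shown here, compound 2 `COc1cccc(-c2ncnc3c2ncn3C2O[C@H](CO)[C@@H](O)[C@H]2O)c1` bears a 3-methoxyphenyl and in this assay compound 2 gives 4800 nM, the highest of the two numbers measured; its only neighbour is compound 1, reached by an 8.0-fold higher number from compound 1 to compound 2 (0.90 log units; beyond the scatter). Compound 3 `OC[C@H]1OC(n2cnc3c(-c4ccc(F)cc4)ncnc32)[C@H](O)[C@@H]1O` is not yet measured. It differs from compound 2 as follows: 4-fluorophenyl in place of 3-methoxyphenyl on an aromatic carbon. Among the measured compounds shown here, the one measured step that bears on this change is an 8.0-fold higher number from compound 1 to compound 2 (0.90 log units; beyond the scatter), which links two aryl groups that differ in both the substituent and where it sits. Compound 3 again carries its substituent in the 4-position, like compound 1, so a move back toward the number of compound 1 is expected, though nothing measured separates the effect of the substituent from that of its position. The estimate for compound 3 is a 4.0-fold lower number from compound 2 to compound 3 (0.60 log units; beyond the scatter). In this assay compound 3 is expected to give 1200 nM, within 300 nM to 4800 nM.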

Compound 3, half-maximal inhibitory concentration: 750 nM
Estimate against measurement, compound 3: 1.6-fold (0.20 log units) above, and the stated range covers the measured number.
By their numbers in this assay, from the lowest: compounds 1 and 3 (each within the scatter of the next); then compound 2.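

In this assay, putting 4-fluorophenyl in place of 3-methoxyphenyl on this aromatic carbon gives a 6.4-fold lower number from compound 2 to compound 3 (0.81 log units; beyond the scatter), while fluoro in place of ethoxy gives a 1.3-fold higher number from compound 1 to compound 3 (0.10 log units; within the scatter). Among these compounds, the earlier pair showed only that compound 1 and compound 2 differ; the new compound shows that two quite different groups on the aryl ring, ethoxy and fluoro, cannot be told apart on this read-out, leaving compound 2 with the highest number of the three, beyond the scatter of both others. Nothing measured on these compounds accounts for either step, so the result stands as a description only.

What the compounds shown leave open is whether the higher number of compound 2 belongs to the methoxy group or to the place it occupies, as the 3-methoxyphenyl differs from both other aryl groups in substituent and in position at once. They also leave open how far this tolerance for different substituents extends, for instance to an unsubstituted phenyl or to an aryl ring carrying an amine or a carboxylic acid.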